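A few compounds are considered here, and "the series" means these few. Any claim that something is new, unique, unknown or untested is made for them only; others in the source may bear on it.

Measured so far in a functional assay on BE(2)-C cells (Homo sapiens) for inhibition, read by MTT assay, with a stated time of 72 h; a higher number here means a weaker inhibitor of growth, a lower number a stronger inhibitor of growth:
- Compound 1, `O=S(=O)(NCCCNCC1COc2ccccc2O1)c1cc(C(F)(F)F)cc(C(F)(F)F)c1`: 2800 nM
- Compound 2, `O=S(=O)(NCCCNCc1ccccc1)c1cc(C(F)(F)F)cc(C(F)(F)F)c1`: 12000 nM

Compound 2 holds the highest of the two numbers, so it is the weaker inhibitor of growth among them; its nearest neighbour is compound 1, and the step of a 4.3-fold higher number from compound 1 to compound 2 (0.63 log units; beyond the scatter) lies beyond the scatter. Compound 3, `O=S(=O)(NCCCNCc1cccc2ccccc12)c1cc(C(F)(F)F)cc(C(F)(F)F)c1`, has not yet been measured. It differs from compound 2 in one place: naphthalen-1-yl in place of phenyl on a saturated chain carbon bound to an amine nitrogen. Going by the values given here, only one measured step bears on this change: a 4.3-fold higher number from compound 1 to compound 2 (0.63 log units; beyond the scatter), in which swapping the 2,3-dihydro-1,4-benzodioxin-2-yl group for phenyl on that chain carbon went with a weaker inhibitor of growth. Naphthalen-1-yl is not the same group as the one on compound 1, so this step is only a loose guide, and the direction of the earlier step is the main hint. On that basis compound 3 is expected to show a modest lowering of the number against compound 2, a 2.7-fold lower number from compound 2 to compound 3 (0.43 log units; beyond the scatter). For compound 3 the estimated value is 4500 nM, with a range from 1500 nM to 14000 nM.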

Compound 3, concentration for 50% growth inhibition: 2700 nM
For compound 3 the middle estimate is 1.7-fold (0.22 log units) above the measured one, and the stated range covers the measured number.
By their numbers in this assay, from the lowest: compounds 3 and 1 (each within the scatter of the next); then compound 2.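

In this assay, naphthalen-1-yl in place of phenyl on a saturated chain carbon bound to an amine nitrogen brings a clear gain (a 4.4-fold lower number from compound 2 to compound 3 (0.65 log units; beyond the scatter)), so the number at this position can fall again without returning to the group on compound 1. The comparison with that compound (a 1.0-fold lower number from compound 1 to compound 3 (0.02 log units; within the scatter)) lies within the scatter, which means that naphthalen-1-yl, a group of carbon only, and 2,3-dihydro-1,4-benzodioxin-2-yl cannot be told apart in this growth test, and among these three compounds only the phenyl group of compound 2 stands apart. No supporting measurement is available to explain why the two larger groups give similar numbers or why phenyl gives a higher one.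

Still open, as far as these compounds go, is whether the second ring of naphthalen-1-yl matters in itself or whether a smaller addition, such as a methoxy group on the phenyl ring, would give a similar gain. Also open, from the compounds shown here alone, are how naphthalen-2-yl, with the same atoms joined to the chain through a different ring carbon, would compare with naphthalen-1-yl, and whether a longer chain in the shared core would change the size of these steps.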